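Ethoxy in place of fluoro on the shared core

The source may report more compounds than this note shows. Statements on the series, on what has been measured and on what is new or still open speak of the compounds shown alone.

Compound 1, `Cc1ccc2nc(C(=O)Nc3c(F)cc(-c4cccc(F)c4)cc3F)c(C)c(C(=O)O)c2c1`, gives 1.05% in a functional assay on Hep 3B2 cells (Homo sapiens) for antiproliferative activity, read by MTT assay, with a stated time of 24 h, tested at 0.02 ug/mL; on this read-out lower numbers stand for a weaker effect and higher numbers for a stronger effect at the one concentration tested.
Compound 2, `CCc1ccc2nc(C(=O)Nc3c(F)cc(-c4cccc(F)c4)cc3F)c(C)c(C(=O)O)c2c1`, gives -0.05% in this assay.
Compound 3, `Cc1c(C(=O)Nc2c(F)cc(-c3cccc(F)c3)cc2F)nc2ccc(F)cc2c1C(=O)O`, gives -0.13% in this assay.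

All three numbers sit close to zero and within the scatter of one another, so compound 3 cannot be set apart from compound 1 or compound 2 on these data. The steps measured so far, a number 1.1 percentage points lower from compound 1 to compound 2 (within the scatter), a number 1.2 percentage points lower from compound 1 to compound 3 (within the scatter) and a number 0.1 percentage points lower from compound 2 to compound 3 (within the scatter), all change the same aromatic carbon of the shared core, and none of them moved the read-out beyond the scatter.

Compound 4, `CCOc1ccc2nc(C(=O)Nc3c(F)cc(-c4cccc(F)c4)cc3F)c(C)c(C(=O)O)c2c1`, differs from compound 3 by ethoxy in place of fluoro on an aromatic carbon. Within the data shown here, this is the same position on which the three measured steps were silent, and nothing among the measured compounds suggests that an ethoxy group there would behave differently. No step beyond the scatter is therefore expected in this assay; the expected step is a number 0.4 percentage points higher from compound 3 to compound 4 (within the scatter). Compound 4 is expected to give about 0.3%, in the range -8% to 8%.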

Compound 4, a percentage reported as inhibition, at one concentration (the size of the read-out at that concentration, not a potency): 0.05%
Compound 4: middle estimate off by 0.3 percentage points, on the high side; low and high end bracket the measured number.
By their numbers in this assay, from the lowest: compounds 3, 2, 4 and 1 (each within the scatter of the next).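

Ethoxy is the first group on this aromatic carbon that carries oxygen, and in this assay it still gives no step beyond the scatter: a number 0.2 percentage points higher from compound 3 to compound 4 (within the scatter), a number 0.1 percentage points higher from compound 2 to compound 4 (within the scatter) and a number 1 percentage points lower from compound 1 to compound 4 (within the scatter). Fluoro, methyl, ethyl and ethoxy on this carbon therefore cannot be told apart at the one concentration tested, and the change from a single heavy atom to the three of ethoxy leaves the read-out near zero. No supporting data bear on this result.

Still open, on these data alone, is whether an amine, a hydroxyl or a longer alkoxy chain on this carbon would move the read-out beyond the scatter. Also open, as far as these compounds go, is whether these four compounds would separate at a higher concentration or with a longer exposure.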